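Aryl replacement at the core of compound 2

The source may report more compounds than this note shows. Statements on the series, on what has been measured and on what is new or still open speak of the compounds shown alone.

Compound 2, structure `CCOC(=O)c1cnc(-c2cccs2)nc1NN1C(=O)C=C(C)C1=O`, gives 20 nM in a functional assay on Jurkat cells for inhibition of nuclear factor NF-kappa-B complex (Homo sapiens) (on this read-out lower numbers stand for stronger inhibition and higher numbers for weaker inhibition), and holds the lowest number of the three measured. Compound 1, structure `CCOC(=O)c1cnc(SC)nc1NN1C(=O)C=C(C)C1=O`, gives 200 nM; the step of a 10-fold lower number from compound 1 to compound 2 (1.00 log units; beyond the scatter) marks a modest gain. Compound 3, structure `CCOC(=O)c1cnc(-n2nc(C)cc2C)nc1NN1C(=O)C=C(C)C1=O`, gives 10000 nM; the steps of a 50-fold higher number from compound 1 to compound 3 (1.70 log units; beyond the scatter) and a 500-fold higher number from compound 2 to compound 3 (2.70 log units; beyond the scatter) are large losses.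

Compound 4, structure `CCOC(=O)c1cnc(-c2ccc(OC)cc2)nc1NN1C(=O)C=C(C)C1=O`, differs from compound 2 by 4-methoxyphenyl in place of thiophen-2-yl on an aromatic carbon. Going by the values given here, the steps that bear on it are those at the same aromatic carbon: a 10-fold lower number from compound 1 to compound 2 (1.00 log units; beyond the scatter) shows that a five-membered aromatic ring with one hetero atom is favoured over methylsulfanyl, while a 500-fold higher number from compound 2 to compound 3 (2.70 log units; beyond the scatter) shows a nitrogen-linked five-membered ring is strongly disfavoured. Among the compounds with values here, a six-membered aromatic ring of carbon only has no precedent here, so the outcome is open; a step near the scatter, or a modest loss, is expected rather than another large shift.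

Compound 4 is therefore estimated at 40 nM, with a range from 10 nM to 200 nM, meaning an expected step of a 2.0-fold higher number from compound 2 to compound 4 (0.30 log units; within the scatter).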

Compound 4, half-maximal inhibitory concentration: 900 nM
Compound 4: the middle estimate sits 23-fold (1.35 log units) below what was measured; measured number outside the range, above it.
By their numbers in this assay, from the lowest: compound 2; then compound 1; then compound 4; then compound 3.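

In this assay, a carbon-linked aromatic ring at this position does not by itself keep the gain seen with thiophen-2-yl: 4-methoxyphenyl gives a 45-fold higher number from compound 2 to compound 4 (1.65 log units; beyond the scatter) and also falls behind methylsulfanyl, with a 4.5-fold higher number from compound 1 to compound 4 (0.65 log units; beyond the scatter) as the modest loss. The same group still stands ahead of 3,5-dimethyl-1H-pyrazol-1-yl, as an 11-fold lower number from compound 3 to compound 4 (1.05 log units; beyond the scatter) shows, so the read-out depends on which ring sits on this carbon and not merely on whether a ring is present. No measurement at hand accounts for these differences.

The step to 4-methoxyphenyl changes the ring and adds a methoxy group at once, and the compounds shown cannot separate these two changes. Plain phenyl would divide that step, while furan-2-yl would test whether the gain extends beyond thiophen-2-yl.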